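Pyrazolylamino triazolopyrimidines: thioether substituent change

The compounds below may be only part of what the source reports. "The series", "measured", "known", "first", "only" and "open" are said of these compounds alone.

Measured compounds:
compound 1 `Cc1cc(Nc2ccn(Cc3cccc4ccccc34)n2)n2nc(SCc3ccc(Br)cc3)nc2n1` 4310 nM
compound 2 `Cc1cc(Nc2cc(-c3ccccc3)[nH]n2)n2nc(SCc3cccc(Br)c3)nc2n1` 5140 nM

Both compounds were tested in a functional assay on MCF7 cells (Homo sapiens) for inhibition, read by MTT assay, with a stated time of 72 h; a higher number here means a weaker inhibitor, a lower number a stronger inhibitor. Compound 2 has the higher of the two numbers, but it lies within the scatter of compound 1, so no order between them can be stated.

Compound 3 `Cc1cc(Nc2cc(-c3ccccc3)[nH]n2)n2nc(SCC3CCCCC3)nc2n1` is not yet measured. Relative to compound 2 it carries cyclohexyl in place of 3-bromophenyl on a saturated chain carbon bound to a sulfur. For the measured compounds named here, no measured pair shows the effect of such a change, so no direction is supported; the step from compound 2 to compound 3 is expected to be a 1.2-fold higher number from compound 2 to compound 3 (0.07 log units; within the scatter), most likely not beyond the scatter. Compound 3 is estimated at 6000 nM, with a range from 2500 nM to 15000 nM.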

Compound 3, half-maximal inhibitory concentration: > 50000 nM
Compound 3 gave a limit, no number (the forecaster's own chance of this, stated with the estimate: 10%); at least 8.3-fold (0.92 log units) between middle value and limit.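

In this assay, for the compounds shown here, the first step at this position is large: cyclohexyl in place of 3-bromophenyl on a saturated chain carbon bound to a sulfur gives an at least 9.7-fold higher number from compound 2 to compound 3 (0.98 log units; beyond the scatter). The thioether substituent is therefore not interchangeable here, even though the two groups are similar in size by heavy-atom count. Compound 3 gives a limit and not a number, so the full size of the step cannot be read: the limit of > 50000 nM in this assay, at which 1 of the 3 values shown sits.

On these data alone, it remains open whether the loss follows the non-aromatic ring or the absent bromine. A plain benzyl group at this place would separate the two.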